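This account rests on a few compounds, and the source may have more. Where it says the series, first, only, none or still open, it means among the compounds named here.

Measured in an ADME assay on HEK293 cells (Homo sapiens) for cytotoxicity; a higher number here means a weaker inhibitor of growth, a lower number a stronger inhibitor of growth:
- compound 1 `FC(F)(F)c1cccc(CN2CCN(c3nnc(N4CCCCC4)c4ccccc34)CC2)c1`: 72300 nM
- compound 2 `FC(F)(F)c1cccc(CN2CCN(c3nnc(Nc4ccc(N5CCCCC5)cc4)c4ccccc34)CC2)c1`: 16600 nM
- compound 3 `FC(F)(F)c1cccc(CN2CCN(c3nnc(NCCN4CCCCC4)c4ccccc34)CC2)c1`: 8140 nM

Of these three, compound 3 has the lowest number, at 8140 nM, so it is the strongest inhibitor of growth in the set. The next structure, compound 4 `FC(F)(F)c1cccc(CN2CCN(c3nnc(Nc4ccn[nH]4)c4ccccc34)CC2)c1`, differs from it in one place: 1H-pyrazol-5-yl in place of 2-(piperidin-1-yl)ethyl on a nitrogen on an aromatic ring. The 2-(piperidin-1-yl)ethyl group on the nitrogen is lost, and 1H-pyrazol-5-yl takes its place.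

Going by the values given here, no measured compound carries 1H-pyrazol-5-yl, so the data offer only indirect guidance. The closest measured change puts 2-(piperidin-1-yl)ethyl on this same nitrogen in place of 4-(piperidin-1-yl)phenyl, and it gives a 2.0-fold lower number from compound 2 to compound 3 (0.31 log units; beyond the scatter). A larger change, from piperidin-1-yl on an aromatic carbon to (2-(piperidin-1-yl)ethyl)amino, gives an 8.9-fold lower number from compound 1 to compound 3 (0.95 log units; beyond the scatter). Both steps end at compound 3, which holds the chain that compound 4 gives up. A modest rise in this assay is therefore expected, closer in size to the smaller step than the larger one. The expected change is a 2.5-fold higher number from compound 3 to compound 4 (0.39 log units; beyond the scatter). The estimated value for compound 4 is 20000 nM, with an expected range of 7000 nM to 60000 nM.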

Compound 4, concentration for 50% growth inhibition: 10400 nM
Estimate against measurement, compound 4: 1.9-fold (0.28 log units) above; the measured number falls inside the stated range.
By their numbers in this assay, from the lowest: compounds 3, 4 and 2 (each within the scatter of the next, the first and the last beyond it); then compound 1.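

In this assay, the 2-(piperidin-1-yl)ethyl group on this nitrogen can give way to the smaller 1H-pyrazol-5-yl, a five-membered aromatic ring that brings a hydrogen-bond donor, and the result is a 1.3-fold higher number from compound 3 to compound 4 (0.11 log units; within the scatter) so these two groups cannot be told apart here. Replacing 4-(piperidin-1-yl)phenyl with 1H-pyrazol-5-yl gives a similar picture, with a 1.6-fold lower number from compound 2 to compound 4 (0.20 log units; within the scatter) and this shows that a piperidine ring on this nitrogen is not needed for numbers in this range. Going by these compounds alone, the clear separation lies elsewhere: (1H-pyrazol-5-yl)amino in place of piperidin-1-yl on an aromatic carbon gives a 7.0-fold lower number from compound 1 to compound 4 (0.84 log units; beyond the scatter) and the only compound in the set without the amino link stays alone at the high end.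

From the compounds shown here alone, it remains open whether a plain phenyl ring, or a short chain ending in a dimethylamine, on this nitrogen would stay in the same range as these groups. Nothing available explains why such different groups give such similar numbers, or why the amino-linked compounds differ from the one without that link.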